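The source may hold more compounds than are shown below. What is called first, only, known or untested is meant among the compounds shown, and "the series" means these compounds.

Working notes on the series. Two compounds have a reading so far in an ADME assay (liver) for metabolic stability, with Liver microsome (Rattus norvegicus) as the target, read by LC-MS, using microsomes and NADPH, with stated times of 5 min and 60 min, tested at 4 uM; a higher number here means that more of the compound is left, a lower number that less of the compound is left. Compound 1 (`Cc1c(OCCCCOc2ccc(C(=O)O)cc2F)ccc(C(=O)CC2CCCC2)c1O`) gives 66%, and compound 2 (`COc1cc(C(=O)O)ccc1OCCCCOc1ccc(C(=O)CC(C)C)c(O)c1C`) gives 43%. Compound 2 is the lower of the two, and the gap between them lies beyond the usual scatter. For the measured compounds named here, no pair of measured compounds differs in only one place, so no single change has a measured size.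

The next compound is compound 3 (`Cc1c(OCCCCOc2ccc(C(=O)O)cc2F)ccc(C(=O)CC(C)C)c1O`). It has fluoro in place of methoxy on an aromatic carbon of compound 2 (fluoro in place of methoxy on an aromatic carbon), at a place ortho to a large group and meta to a carboxy group. A modest upward move in this assay is expected, close to the size of the scatter. Going by the values given here, the only guide is the spread from compound 2 at 43% to compound 1 at 66%, and the expectation is centred inside that spread. The estimated change is a number 11 percentage points higher from compound 2 to compound 3 (beyond the scatter). In this assay the expected value for compound 3 is 54%, with an estimated range of 40% to 68%.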

Compound 3, percent of the compound remaining: 57%
Beside the measured number, compound 3's estimate is 3 percentage points below it, within the range that was stated.
By their numbers in this assay, from the lowest: compound 2; then compounds 3 and 1 (each within the scatter of the next).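

In this assay, fluoro in place of methoxy on an aromatic carbon, at the place ortho to a large group and meta to a carboxy group, now has a measured size: a number 14 percentage points higher from compound 2 to compound 3 (beyond the scatter). Isopropyl in place of cyclopentyl on a saturated chain carbon bound to a carbonyl carbon gives a number 9 percentage points lower from compound 1 to compound 3 (within the scatter), so of the two places where compound 1 and compound 2 differ, only the aromatic position has a step beyond the scatter. Nothing measured here accounts for the size of either step.

On these data alone, it remains open whether another group at this aromatic carbon, such as chloro or a nitrile, would read closer to fluoro or to methoxy. Also open, as far as these compounds go, is whether the step from methoxy to fluoro keeps its size with cyclopentyl in place of isopropyl, as a single pair at one position cannot show whether it carries over to other compounds.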